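Replacing the halogenated ring with an ethoxypropenyl chain

The source may report more compounds than this note shows. Statements on the series, on what has been measured and on what is new or still open speak of the compounds shown alone.

Measured so far:
compound 1 `COC(=O)/C=C/c1cccc(N(Cc2ccc(-c3cccc(Cl)c3)cc2)C(=O)C2CCCCC2)c1` — 94 nM
compound 2 `COC(=O)/C=C/c1cccc(N(Cc2ccc(-c3ccc(F)c(Cl)c3)cc2)C(=O)C2CCCCC2)c1` — 66 nM
compound 3 `COC(=O)/C=C/c1cccc(N(Cc2ccc(-c3ccc(N(C)C)cc3)cc2)C(=O)NC(C)C)c1` — 162 nM

In an assay on isolated protein with Bile acid receptor (Homo sapiens) as the target (a higher number here means that more compound is needed for the effect, a lower number that less compound is needed), compound 2 gives 66 nM, the lowest of the three numbers; compound 1 with 94 nM lies within the scatter of it, and only compound 3 with 162 nM stands beyond. Compound 4 `CCOC/C=C/c1ccc(CN(C(=O)C2CCCCC2)c2cccc(/C=C/C(=O)OC)c2)cc1` carries 3-ethoxyprop-1-en-1-yl in place of 3-chloro-4-fluorophenyl on an aromatic carbon. Among the measured compounds shown here, the single measured step, a 1.4-fold lower number from compound 1 to compound 2 (0.15 log units; within the scatter), concerns only a substituent on the ring that now leaves and lies within the scatter, so no measured step bears directly on removing that ring. Compound 3 also lacks the halogenated ring but differs in two further places. A rise in the number is expected, of uncertain size. For compound 4 the estimate is 300 nM, range 100 nM to 1000 nM, so a 4.5-fold higher number from compound 2 to compound 4 (0.66 log units; beyond the scatter) is expected.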

Compound 4, half-maximal effective concentration: 198000 nM
The estimate for compound 4 lay 660-fold (2.82 log units) below the measured number, and the stated range ends below it.
By their numbers in this assay, from the lowest: compounds 2, 1 and 3 (each within the scatter of the next, the first and the last beyond it); then compound 4.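

Among the compounds shown here, at the position para to a large group, the earlier steps changed only a substituent on the aryl ring, whereas replacing the whole ring in this assay gives a 3000-fold higher number from compound 2 to compound 4 (3.48 log units; beyond the scatter) and, with 3-chlorophenyl as the group that leaves, a 2100-fold higher number from compound 1 to compound 4 (3.32 log units; beyond the scatter) as well. The two steps agree, so this change is far from neutral at this position on either halogenated parent. Nothing available accounts for the size of this rise.

Open, from the compounds shown here alone, is whether the ring itself or the ether oxygen of the entering chain decides the outcome. An unsubstituted phenyl, a pyridine ring or an all-carbon pentenyl chain at this position could separate these.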